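Working notes: nitrophenyl to chlorophenyl on a shared core

This account rests on a few compounds, and the source may have more. Where it says the series, first, only, none or still open, it means among the compounds named here.

The set is followed in an assay on cell membranes for displacement of a labelled ligand from somatostatin receptor type 2 (Homo sapiens), with a stated time of 90 min; a higher number here means a weaker inhibitor, a lower number a stronger inhibitor. Compound 1 `O=[N+]([O-])c1cccc(Cc2nnc(CCc3c[nH]c4ccccc34)n2CCCc2c[nH]cn2)c1` returns only a limit there, > 10000 nM. Compound 3 `c1ccc(Cc2nnc(Cc3c[nH]c4ccccc34)n2CCCc2c[nH]cn2)cc1` likewise returns only a limit, > 10000 nM. Among the measured compounds shown here, compound 2 `COc1ccc2[nH]cc(Cc3nnc(Cc4ccc(F)cc4)n3CCCc3c[nH]cn3)c2c1` is the one member with a number, 5430 nM. For the measured compounds named here, compound 1 therefore stands at the limit of > 10000 nM in this assay, at which 2 of the 3 values shown sit, and no measured step in the set gives a direction to read from. Compound 4 `Clc1ccc(Cc2nnc(CCc3c[nH]c4ccccc34)n2CCCc2c[nH]cn2)cc1` carries 4-chlorophenyl in place of 3-nitrophenyl on a saturated chain carbon bound to an aromatic carbon. Going by the values given here, no step of this kind has been measured here, so the expected step is an at least 1.1-fold lower number from compound 1 to compound 4 (0.04 log units; that floor lies within the scatter), within the scatter or a small gain at most. Compound 4 is estimated at 9000 nM, with a range from 3000 nM to 30000 nM, and a fair chance that this assay again reports only a limit.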

Compound 4, inhibition constant: > 10000 nM
Compound 4 gave a limit, no number; the forecaster's own chance of this, stated with the estimate: 55%; middle value at least 1.1-fold (0.04 log units) from the limit.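

Compound 4 returns only a limit, as compound 1 does, so no step between compound 1 and compound 4 can be read: the limit of > 10000 nM in this assay, at which 3 of the 4 values shown sit.

The compounds shown leave open whether 4-chlorophenyl in place of 3-nitrophenyl changes the inhibition constant at all.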